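Series notes: amide side chain on the shared core

The compounds below may be only part of what the source reports. "The series", "measured", "known", "first", "only" and "open" are said of these compounds alone.

The compounds are compared in a functional assay on HEK293 cells for agonist activity at G-protein coupled receptor 39 (Homo sapiens), read by scintillation proximity assay and inositol phosphate accumulation, with a stated time of 75 min, in the presence of a further agent that is not named here; a higher number here means that more compound is needed for the effect, a lower number that less compound is needed. Compound 1 `Cc1nn(-c2ncnc3nc[nH]c23)c2c1C(C(=O)NCc1ccc(F)cc1)CC(=O)N2` gives 4 nM. Compound 2 `Cc1cc(C)n(CCOC2CC(=O)Nc3c2c(C)nn3-c2ncnc3nc[nH]c23)n1` gives 16 nM, the second highest of the three numbers; its nearest neighbour is compound 1, which sits beyond the scatter below it, and its furthest is compound 3 `CC(C)(C)c1cc(C(=O)N/N=C/c2ccc(O)cc2O)[nH]n1`, which gives 240 nM in this assay, well beyond the scatter above it.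

Compound 4 `Cc1nn(-c2ncnc3nc[nH]c23)c2c1C(NC(=O)c1ccccc1)CC(=O)N2` has not been measured. Compared with compound 2, the change is a group of 9 heavy atoms (7 carbon, 1 nitrogen, 1 oxygen; one six-membered aromatic ring of carbon only) in place of a group of 10 heavy atoms (7 carbon, 2 nitrogen, 1 oxygen; one five-membered aromatic ring with 2 hetero atoms), on a saturated ring carbon. The benzamido group that enters puts an amide on the saturated ring carbon, which brings compound 4 closer in make-up to compound 1 than compound 2 is, and compound 1 gives 4 nM in this assay.

Because compound 1 gives 4 nM with an amide at the same place, the step of a 2.0-fold lower number from compound 2 to compound 4 (0.30 log units; within the scatter) is expected to lower the number modestly, though it may stay within the scatter. For compound 4 the expected value in this assay is 8 nM, with a range from 2 nM to 40 nM.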

Compound 4, half-maximal effective concentration: 3 nM
For compound 4 the middle estimate is 2.7-fold (0.43 log units) above the measured one; low and high end bracket the measured number.
By their numbers in this assay, from the lowest: compounds 4 and 1 (each within the scatter of the next); then compound 2; then compound 3.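

In this assay, the benzamido group on the saturated ring carbon, in place of the group carrying the five-membered aromatic ring, gives a 5.3-fold lower number from compound 2 to compound 4 (0.73 log units; beyond the scatter), so this position responds to the group it carries. Compound 4 and compound 1 lie within the scatter of each other, so the benzamido group and the amide side chain of compound 1 do not separate at this ring carbon. Nothing measured on these compounds accounts for the step from the group with the five-membered ring to benzamido.

The step changes the ring and the link to the core together, so the share of each in the result stays unresolved. Going by these compounds, whether the benzene ring is needed at all remains open, and an acetamido group or a free amine on the same carbon would bear on that.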